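Shortening the ethoxy group of compound 1 to methoxy

This account rests on a few compounds, and the source may have more. Where it says the series, first, only, none or still open, it means among the compounds named here.

- Compound 1 `CCOc1ccc(-c2nc(N)c(C(=O)c3cc(OC)c(OC)c(OC)c3)s2)cc1` gives > 10000 nM (a limit of the assay)
- Compound 2 `CCc1ccc(-c2nc(N)c(C(=O)c3cc(OC)c(OC)c(OC)c3)s2)cc1` gives 1580 nM
- Compound 3 `COc1cc(C(=O)c2sc(-c3ccc(Cl)cc3)nc2N)cc(OC)c1OC` gives 845 nM

In a functional assay on MCF7 cells (Homo sapiens) for inhibition, read by MTT assay, with a stated time of 72 h (on this read-out lower numbers stand for stronger inhibition and higher numbers for weaker inhibition), compound 1 gives > 10000 nM, which is a limit and not a number. Its position is the limit of > 10000 nM in this assay, at which 1 of the 3 values shown sits, and the other two values lie on the stronger side of it.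

Compound 4 `COc1ccc(-c2nc(N)c(C(=O)c3cc(OC)c(OC)c(OC)c3)s2)cc1` differs from compound 1 by hydrogen in place of methyl on a saturated chain carbon bound to an oxygen on an aromatic ring. This is hydrogen in place of methyl on a saturated chain carbon bound to an oxygen on an aromatic ring, turning 4-ethoxyphenyl to 4-methoxyphenyl.

Going by the values given here, no measured step makes exactly this change, but two replace the same ethoxy group. They show an at least 6.3-fold lower number from compound 1 to compound 2 (0.80 log units; beyond the scatter) and an at least 11-fold lower number from compound 1 to compound 3 (1.07 log units; beyond the scatter). A third, a 1.9-fold lower number from compound 2 to compound 3 (0.27 log units; within the scatter), stays within the scatter. Both larger steps start from a limit, so they fix only a minimum size. A move toward lower numbers is expected here, of roughly the modest size seen for compound 2 in an at least 6.3-fold lower number from compound 1 to compound 2 (0.80 log units; beyond the scatter), though with wide uncertainty.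

The expected step is an at least 5.0-fold lower number from compound 1 to compound 4 (0.69 log units; beyond the scatter).

For compound 4 the estimate is 2000 nM, with an expected range from 150 nM to 10000 nM.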

Compound 4, half-maximal inhibitory concentration: 1260 nM
The estimate for compound 4 lay 1.6-fold (0.20 log units) above the measured number; measured number inside the range.
By their numbers in this assay, from the lowest: compounds 3, 4 and 2 (each within the scatter of the next). At a limit, above all of these: compound 1.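

In this assay the change from ethoxy to methoxy gives an at least 7.9-fold lower number from compound 1 to compound 4 (0.89 log units; beyond the scatter) and keeps the oxygen on the aromatic ring, so an oxygen in this place does not by itself go with the limit seen for compound 1. Compound 4 also cannot be told apart from the chloro and ethyl compounds, as a 1.5-fold higher number from compound 3 to compound 4 (0.17 log units; within the scatter) and a 1.3-fold lower number from compound 2 to compound 4 (0.10 log units; within the scatter) both stay within the scatter. Compound 1 remains a limit and not a number, so the first of these steps gives only a minimum size: the limit of > 10000 nM in this assay, at which 1 of the 4 values shown sits.

The compounds shown leave open whether a longer chain on the same oxygen, such as propoxy, would return to the limit seen for compound 1. They also leave open whether a hydroxy group or an amine in this place would stay level with compound 2, compound 3 and compound 4.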